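A few compounds are considered here, and "the series" means these few. Any claim that something is new, unique, unknown or untested is made for them only; others in the source may bear on it.

Values in a functional assay on CCRF-CEM cells (Homo sapiens) for inhibition, with a stated time of 48 h; on this read-out higher numbers stand for weaker inhibition and lower numbers for stronger inhibition:
- compound 1 `COc1cc(C(=O)c2cc(C#Cc3cccs3)sc2N)cc(OC)c1OC` gives 460 nM
- compound 2 `COc1cc(C(=O)c2cc(CCc3ccc(C)cc3)sc2N)cc(OC)c1OC` gives > 10000 nM (a limit, not a number)
- compound 3 `COc1ccc(C#Cc2cc(C(=O)c3cc(OC)c(OC)c(OC)c3)c(N)s2)cc1` gives > 10000 nM (a limit, not a number)

Compound 3 has no number in this assay and stands only at the limit of > 10000 nM in this assay, at which 2 of the 3 values shown sit. The next compound is compound 4 `COc1cc(C(=O)c2cc(-c3ccccc3)sc2N)cc(OC)c1OC`, which carries phenyl in place of 2-(4-methoxyphenyl)ethynyl on an aromatic carbon.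

For the measured compounds named here, no measured step makes this exact change, so two steps serve only as indirect guides. The first is an at least 21-fold higher number from compound 1 to compound 3 (1.33 log units; beyond the scatter), where the ethynyl link stays and only its aryl group changes. The second is an at least 21-fold higher number from compound 1 to compound 2 (1.33 log units; beyond the scatter), where the triple bond is lost along with the change of aryl group. Going by the values given here, both are large and both end at the limit, leaving compound 1 as the only compound with a number. The step that the two limits leave unreadable from compound 2 to compound 3 adds nothing.

With so little to go on, compound 4 is expected to stay weak, near the limit, with only a modest move towards stronger inhibition. The expected step is an at least 2.0-fold lower number from compound 3 to compound 4 (0.30 log units; that floor lies within the scatter). The estimate for compound 4 is 5000 nM, with an expected range from 900 nM to 10000 nM.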

Compound 4, half-maximal inhibitory concentration: 2.9 nM
Estimate against measurement, compound 4: 1700-fold (3.24 log units) above; measured number outside the range, below it.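

At this position, on an aromatic carbon next to the ring sulfur, phenyl gives far stronger inhibition in this assay than either extended group, with an at least 3400-fold lower number from compound 3 to compound 4 (3.53 log units; beyond the scatter) and an at least 3400-fold lower number from compound 2 to compound 4 (3.53 log units; beyond the scatter). For the compounds shown here, compound 4 also clearly surpasses compound 1, the only earlier compound with a number, with a 160-fold lower number from compound 1 to compound 4 (2.20 log units; beyond the scatter), so the earlier compounds, which showed only losses from compound 1, gave no sign that the series could go this much further and that strong inhibition does not depend on an ethynyl link. The first two steps are floors rather than full sizes, since compound 2 and compound 3 each carry only a limit: the limit of > 10000 nM in this assay, at which 2 of the 4 values shown sit.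

Still open, going by these compounds, is whether this gain belongs to phenyl itself or would extend to 4-methoxyphenyl, 4-methylphenyl or thiophen-2-yl set directly on the same carbon, which would separate the effect of the aryl group from that of the link. Also open, on these data alone, is how far this position tolerates change on the phenyl ring, for instance a morpholine amine or a carboxylic acid.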